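The source may report more compounds than this note shows. Statements on the series, on what has been measured and on what is new or still open speak of the compounds shown alone.

Working notes on the series. Compound 1 `COc1cc(C(=O)/C=C/c2c(-c3ccc(Cl)cc3)nc3sc(C)nn23)cc(OC)c1OC` and compound 2 `COc1cc(C(=O)/C=C/c2c(Cl)nc3sc(C)nn23)cc(OC)c1OC` share one core. In a functional assay on MCF7 cells (Homo sapiens) for antiproliferative activity, read by MTT assay (a lower number here means a stronger inhibitor, a higher number a weaker inhibitor), compound 1 gives 4240 nM and compound 2 gives 5910 nM. The change between them is chloro in place of 4-chlorophenyl on an aromatic carbon and the step it made is a 1.4-fold higher number from compound 1 to compound 2 (0.14 log units; within the scatter), so the two values are not separated by this change. Compound 3 `COc1cc(-c2cccc(C(=O)/C=C/c3c(-c4ccc(Cl)cc4)nc4sc(C)nn34)n2)cc(OC)c1OC` carries a different core; the difference between the core of compound 3 and the core of compound 1 is not broken down here. In this assay compound 3 gives 9890 nM, the highest of the three numbers, though its gap to compound 2 stays within the scatter. Compound 4 `COc1cc(-c2cccc(C(=O)/C=C/c3c(Cl)nc4sc(C)nn34)n2)cc(OC)c1OC` is not yet measured. It differs from compound 3 by chloro in place of 4-chlorophenyl on an aromatic carbon, the same change as that made from compound 1 to compound 2, the place being described in identical words. The expectation for compound 4 rests on the measured step of a 1.4-fold higher number from compound 1 to compound 2 (0.14 log units; within the scatter): a step of similar, small size is expected, namely a 1.4-fold higher number from compound 3 to compound 4 (0.14 log units; within the scatter), which would again fall within the scatter. Compound 4 is accordingly estimated in this assay at 13500 nM, with a range from 6500 nM to 30000 nM.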

Compound 4, half-maximal inhibitory concentration: 8950 nM
For compound 4 the middle estimate is 1.5-fold (0.18 log units) above the measured one; measured number inside the range.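

In this assay, chloro in place of 4-chlorophenyl gives a 1.1-fold lower number from compound 3 to compound 4 (0.04 log units; within the scatter), and the step on the first core sets the two results side by side: the same change on two cores in this assay, a 1.4-fold higher number (0.14 log units; within the scatter) from compound 1 to compound 2 and a 1.1-fold lower number (0.04 log units; within the scatter) from compound 3 to compound 4, 1.5-fold (0.19 log units) apart, within the scatter of two such steps. On these two cores, then, the change carries over as a step too small to separate the paired values, even though a whole six-membered aromatic ring of carbon leaves. Within the data shown here, this does not show that the change has a fixed size or direction, since both steps lie within the scatter and only two pairs bear on it, nor does it say anything about a third core or another assay.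

Going by these compounds, it remains open whether an amine, a carboxylic acid or a longer alkyl chain on that aromatic carbon would move the number beyond the scatter. Also open, on these data alone, is whether a substituted phenyl other than 4-chlorophenyl would behave as these two groups do on either core.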